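Sulfonamide series: aryl change on the sulfonamide nitrogen

This account rests on a few compounds, and the source may have more. Where it says the series, first, only, none or still open, it means among the compounds named here.

Compound 1 `CCc1ccc(NS(=O)(=O)c2ccc(N3CCNC3=O)cc2)cc1` carries the shared core with a 4-ethylphenyl on the sulfonamide nitrogen. In a functional assay on MCF7 cells (Homo sapiens) for antiproliferative activity, read by sulforhodamine B assay, with a stated time of 48 h (a higher number here means a weaker inhibitor, a lower number a stronger inhibitor), compound 1 gives 810 nM. Compound 2 `O=C1NCCN1c1ccc(S(=O)(=O)Nc2ccc(OC(F)F)cc2)cc1` gives 760 nM in this assay, and the step of a 1.1-fold lower number from compound 1 to compound 2 (0.03 log units; within the scatter) is within the scatter, so compound 1 and compound 2 sit together on the numbers shown. Compound 3 `CCCCCc1ccc(NS(=O)(=O)c2ccc(N3CCNC3=O)cc2)cc1` reaches only a limit of this assay, > 1000 nM. The step of an at least 1.2-fold higher number from compound 1 to compound 3 (0.09 log units; that floor lies within the scatter) and the step of an at least 1.3-fold higher number from compound 2 to compound 3 (0.11 log units; that floor lies within the scatter) both end at that limit (the limit of > 1000 nM in this assay, at which 1 of the 3 values shown sits).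

Compound 4 `Cc1ccccc1NS(=O)(=O)c1ccc(N2CCNC2=O)cc1` differs from compound 1 at the sulfonamide nitrogen: 2-methylphenyl in place of 4-ethylphenyl on a sulfonamide nitrogen. Among the compounds with values here, no measured step changes this aryl to 2-methylphenyl; the measured steps vary the group on an aromatic carbon of the aryl, and the two numbered values move by a 1.1-fold lower number from compound 1 to compound 2 (0.03 log units; within the scatter) only. Nothing in the series therefore points to a step beyond the scatter; the only larger movement is toward the limit seen for compound 3. Compound 4 is expected at 900 nM, within a range of 450 nM to 1800 nM. The step of a 1.1-fold higher number from compound 1 to compound 4 (0.05 log units; within the scatter) is thus estimated to stay within the scatter.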

Compound 4, half-maximal inhibitory concentration: 280 nM
Compound 4: the middle estimate sits 3.2-fold (0.51 log units) above what was measured, outside the stated range (below it).
By their numbers in this assay, from the lowest: compound 4; then compounds 2 and 1 (each within the scatter of the next). At a limit, above all of these: compound 3.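

In this assay, within the data shown here, 2-methylphenyl in place of 4-ethylphenyl on the sulfonamide nitrogen gives a 2.9-fold lower number from compound 1 to compound 4 (0.46 log units; beyond the scatter), the first step with a number at both ends that lies beyond the scatter. The aryl on this nitrogen can therefore move the number, which the step of a 1.1-fold lower number from compound 1 to compound 2 (0.03 log units; within the scatter) did not show. The change alters the group and its place on the aryl together, so the step cannot be assigned to either one alone, and nothing measured here bears on its cause.

Still open, going by these compounds, is whether 2-ethylphenyl or 4-methylphenyl on the sulfonamide nitrogen would separate the effect of the group from that of its place. Also open, on these data alone, is how an amine or a carboxylic acid on this aryl would read.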